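This account rests on a few compounds, and the source may have more. Where it says the series, first, only, none or still open, it means among the compounds named here.

Within the data shown here, compound 1 `CCCCOc1ccc2c(Cl)ccnc2c1` and compound 2 `CN(C)CCNc1ccnc2cc(OCc3ccccc3)ccc12` share the same core but differ from each other in more than one place, so no single step joins them. In a functional assay on BGC-823 cells (Homo sapiens) for cytotoxicity, read by MTT assay, with a stated time of 48 h (a higher number here means a weaker inhibitor, a lower number a stronger inhibitor), compound 1 gives 3610 nM, the higher of the two numbers measured in this assay. In this assay, among the measured compounds shown here, compound 2 gives 1250 nM, a gap beyond the scatter, yet with two changes between them the values show only that compound 2 is the stronger inhibitor of the pair, not which change matters.

Compound 3 `Clc1ccnc2cc(OCCCc3ccccc3)ccc12` has not yet been measured. It differs from compound 1 in one place: phenyl in place of methyl on a saturated chain carbon, three bonds along the chain from an oxygen on an aromatic ring. For the measured compounds named here, no measured pair shows this change on its own. Going by the values given here, compound 2 is the only compound here that carries an aromatic ring on the chain, and it gives the lower number, but its second change leaves the ring's own share unknown. The expected step is therefore small, a 1.6-fold lower number from compound 1 to compound 3 (0.22 log units; within the scatter), a lowering that may stay within the scatter. Compound 3 is expected to give 2200 nM, with a range from 700 nM to 7000 nM.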

Compound 3, half-maximal inhibitory concentration: 2370 nM
The estimate for compound 3 lay 1.1-fold (0.03 log units) below the measured number; the range from low to high includes it.
By their numbers in this assay, from the lowest: compounds 2, 3 and 1 (each within the scatter of the next, the first and the last beyond it).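

Among these compounds, compound 3 gives the first view of this change on its own: in this assay, putting phenyl in place of methyl on a saturated chain carbon, three bonds along the chain from an oxygen on an aromatic ring, gives a 1.5-fold lower number from compound 1 to compound 3 (0.18 log units; within the scatter) and so cannot be told apart from no change at all. Swapping a single carbon for a six-membered aromatic ring is a large change in size at the end of the chain, yet here it leaves no effect that stands clear of the normal variation between repeat measurements. Nothing available on these compounds offers an explanation for this result.

The compounds shown leave open whether a different group at this chain carbon, such as a carboxylic acid or an amine, or a longer chain, would give a step beyond the scatter. They also leave open how the gap between compound 1 and compound 2 divides between the two changes that separate them, since only the change on the chain has now been seen alone, and only in this one assay on one cell line.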